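Side-chain swap from compound 3 to compound 4

This account rests on a few compounds, and the source may have more. Where it says the series, first, only, none or still open, it means among the compounds named here.

Measured in an ADME assay on the whole organism for pharmacokinetics, with Rattus norvegicus as the target (a lower number here means that the compound disappears faster, a higher number that the compound lasts longer), so far:
- compound 1 `Cc1cc(C)c(NC(=O)c2sccc2S(=O)(=O)Nc2onc(C)c2Cl)c(-c2ncco2)c1` gives 5.3 h
- compound 2 `Cc1cc(C)c(NC(=O)c2sccc2S(=O)(=O)Nc2onc(C)c2Cl)c(C(=O)C2CC2)c1` gives 5.4 h
- compound 3 `Cc1cc(C)c(NC(=O)c2sccc2S(=O)(=O)Nc2onc(C)c2Cl)c(C(=O)CS(C)(=O)=O)c1` gives 12.2 h

Compound 3 stands highest of the three. The change to compound 4 `CO/N=C(\C)c1cc(C)cc(C)c1NC(=O)c1sccc1S(=O)(=O)Nc1onc(C)c1Cl` is a group of 5 heavy atoms (3 carbon, 1 nitrogen, 1 oxygen; no ring) in place of a group of 7 heavy atoms (3 carbon, 3 oxygen, 1 sulfur; no ring), on an aromatic carbon and it removes the ((methylsulfonyl)methyl)carbonyl group. Both steps beyond the scatter lead to that group: a 2.3-fold higher number from compound 1 to compound 3 (0.36 log units; beyond the scatter) and a 2.3-fold higher number from compound 2 to compound 3 (0.35 log units; beyond the scatter) are modest, while a 1.0-fold higher number from compound 1 to compound 2 (0.01 log units; within the scatter) stays within it. Among the measured compounds shown here, the entering group has no measured counterpart, so the range stays wide. A modest fall is expected in this assay toward the level of compound 1 and compound 2. The expected change is a 1.9-fold lower number from compound 3 to compound 4 (0.27 log units; within the scatter) on this reading. For compound 4 the estimated half-life is 6.5 h with an expected range of 3.5 h to 12 h for now.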

Compound 4, half-life: 1.2 h
Compound 4: the middle estimate sits 5.4-fold (0.73 log units) above what was measured, and the stated range ends above it.
By their numbers in this assay, from the lowest: compound 4; then compounds 1 and 2 (each within the scatter of the next); then compound 3.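

In this assay, among the compounds shown here, the entering group gives the first downward step at this aromatic carbon: a 10-fold lower number from compound 3 to compound 4 (1.01 log units; beyond the scatter), alongside a 4.5-fold lower number from compound 2 to compound 4 (0.65 log units; beyond the scatter) and a 4.4-fold lower number from compound 1 to compound 4 (0.65 log units; beyond the scatter). Swaps at this position therefore do not only hold level or rise; a ringless group with the same heavy-atom count as the groups of compound 1 and compound 2 ends lowest of the four. No available measurement bears on the reason for this fall.

Still open, from the compounds shown here alone, is whether an amine, a carboxylic acid or a longer chain ending in methylsulfonyl at this carbon would stay near compound 3 or fall toward compound 4.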